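Trifluoromethyl for Fluoro on the Sulfonyl Aryl Ring

The source may hold more compounds than are shown below. What is called first, only, known or untested is meant among the compounds shown, and "the series" means these compounds.

Measured compounds:
compound 1 `CN1CCN(c2ccc(C3=NN(S(C)(=O)=O)C(c4ccc(N(C)C)cc4)C3)cc2)CC1`: -1.3%
compound 2 `CN1CCN(c2ccc(C3=NN(S(=O)(=O)C4CC4)C(c4ccc(N(C)C)cc4)C3)cc2)CC1`: 0.2%
compound 3 `CN1CCN(c2ccc(C3=NN(S(=O)(=O)c4ccc(F)cc4)C(c4ccc(N(C)C)cc4)C3)cc2)CC1`: 95.7%

The three measured compounds share one core and differ only in the group on the sulfonyl sulfur. In a functional assay on NCI-H1975 cells (Homo sapiens) for inhibition, read by sulforhodamine B assay, tested at 10 uM (on this read-out higher numbers stand for more inhibition at the one concentration tested (going by the name of the read-out) and lower numbers for less inhibition), compound 1 gives -1.3% and compound 2 gives 0.2%; the step of a number 1.5 percentage points higher from compound 1 to compound 2 (within the scatter) separates them. Compound 3 gives 95.7%, the highest of the three, reached through a number 97 percentage points higher from compound 1 to compound 3 (beyond the scatter) and a number 95.5 percentage points higher from compound 2 to compound 3 (beyond the scatter).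

Compound 4 `CN1CCN(c2ccc(C3=NN(S(=O)(=O)c4ccc(C(F)(F)F)cc4)C(c4ccc(N(C)C)cc4)C3)cc2)CC1` keeps the aryl sulfonyl group of compound 3 and differs from it by trifluoromethyl in place of fluoro on an aromatic carbon. For the measured compounds named here, no measured step alters a group on that aromatic ring; the two large steps only show that an aromatic group on the sulfonyl sulfur, rather than methyl or cyclopropyl, goes with high inhibition. Because compound 3 gives 95.7% and compound 4 keeps that aromatic group, the expected step of a number 7.7 percentage points lower from compound 3 to compound 4 (within the scatter) is small, with no direction beyond the scatter. Compound 4 is estimated at 88%, in a range from 45% to 100%.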

Compound 4, a percentage reported as inhibition, at one concentration (the size of the read-out at that concentration, not a potency): 18.9%
Compound 4: middle estimate off by 69.1 percentage points, on the high side; the measured number lies below the stated range.
By their numbers in this assay, from the lowest: compounds 1 and 2 (each within the scatter of the next); then compound 4; then compound 3.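

In this assay the group on the aromatic ring proves decisive, with a number 76.8 percentage points lower from compound 3 to compound 4 (beyond the scatter) on trifluoromethyl in place of fluoro, so among these compounds an aromatic group on the sulfonyl sulfur is not enough for high inhibition. Some gain over the small groups remains, with a number 18.7 percentage points higher from compound 2 to compound 4 (beyond the scatter) and a number 20.2 percentage points higher from compound 1 to compound 4 (beyond the scatter) for the 4-(trifluoromethyl)phenyl group, modest steps set against the large ones seen with 4-fluorophenyl. No measurement at hand bears on the reason for this drop.

The compounds shown leave open how a plain phenyl, or chloro, methoxy, nitrile or an amine at this place on the ring, would read against fluoro and trifluoromethyl. They also leave open whether the same change would have a similar effect on a core carrying other groups.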